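Halogen swap on the fused ring: chloro to fluoro

The source may report more compounds than this note shows. Statements on the series, on what has been measured and on what is new or still open speak of the compounds shown alone.

Compound 3 `Cc1cc(C)n2nc(S(=O)(=O)Nc3c(Cl)ccc4cccnc34)nc2n1` gives 9.4 nM in an assay for inhibition of acetolactate synthase (Nicotiana tabacum); a lower number here means a stronger inhibitor, a higher number a weaker inhibitor. Compound 2 `Cc1cc(C)n2nc(S(=O)(=O)Nc3c(Br)ccc4cccnc34)nc2n1` gives 8.7 nM, and compound 1 `Cc1ccn2nc(S(=O)(=O)Nc3c(F)ccc4cccnc34)nc2n1` gives 17.1 nM. Compound 3 stands second highest of the three numbers; its nearest neighbour is compound 2 and its furthest is compound 1, both within the scatter. Within the data shown here, the one step with a single change, a 1.1-fold higher number from compound 2 to compound 3 (0.03 log units; within the scatter), shows that exchanging one halogen for another at this position leaves the number essentially unchanged.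

Compound 4 `Cc1cc(C)n2nc(S(=O)(=O)Nc3c(F)ccc4cccnc34)nc2n1` differs from compound 3 by fluoro in place of chloro on an aromatic carbon. The step from compound 2 to compound 3 is the direct precedent for a halogen exchange here and was within the scatter. Compound 1 also carries fluoro at this position, on a core with one methyl fewer, and its number sits within the scatter of compound 3, so no shift beyond the scatter is expected in this assay. Compound 4 is therefore expected to give 12 nM, with a range of 6 nM to 25 nM. The expected step of a 1.3-fold higher number from compound 3 to compound 4 (0.11 log units; within the scatter) is estimated to remain within the scatter.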

Compound 4, half-maximal inhibitory concentration: 7.7 nM
For compound 4 the middle estimate is 1.6-fold (0.19 log units) above the measured one; low and high end bracket the measured number.
By their numbers in this assay, from the lowest: compounds 4, 2, 3 and 1 (each within the scatter of the next, the first and the last beyond it).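

In this assay the halogen exchange now extends to fluoro, with a 1.2-fold lower number from compound 3 to compound 4 (0.09 log units; within the scatter) and a 1.1-fold lower number from compound 2 to compound 4 (0.05 log units; within the scatter), so bromo, chloro and fluoro on this aromatic carbon cannot be told apart on the shared core. The methyl change does register with fluoro held fixed: methyl in place of hydrogen on an aromatic carbon of the core gives a 2.2-fold lower number from compound 1 to compound 4 (0.35 log units; beyond the scatter), a modest step and the only one of these three beyond the scatter. Nothing available bears on the reason for either outcome.

The compounds shown leave open how a methoxy group, an amine or a nitrile would fare in place of the halogen in this assay. Also open, from the compounds shown here alone, is whether methyl in place of hydrogen gives a similar step when chloro or bromo is the halogen.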